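The compounds below may be only part of what the source reports. "The series", "measured", "known", "first", "only" and "open" are said of these compounds alone.

Compounds measured so far:
- compound 1 `c1ccc(-c2nc(-c3c[nH]c4ccccc34)co2)cc1` gives 461000 nM in a functional assay on LNCaP cells (Homo sapiens) for cytotoxicity, read by MTT assay, with a stated time of 48 h; on this read-out higher numbers stand for weaker inhibition and lower numbers for stronger inhibition
- compound 2 `Fc1ccc(-c2nc(-c3c[nH]c4ccccc34)co2)cc1` gives 59800 nM in this assay
- compound 3 `c1ccc2c(-c3cocn3)c[nH]c2c1` gives 382000 nM in this assay

Compound 1 stands at the highest number of the three, meaning the weakest inhibition. Its nearest neighbour is compound 3, where the phenyl is replaced by hydrogen: the step is a 1.2-fold lower number from compound 1 to compound 3 (0.08 log units; within the scatter), so taking the phenyl away hardly changes the read-out. Adding a fluoro to that phenyl, as in compound 2, gives a 7.7-fold lower number from compound 1 to compound 2 (0.89 log units; beyond the scatter), a modest move toward stronger inhibition.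

Compound 4 `c1ccc2c(-c3coc(C4CCNCC4)n3)c[nH]c2c1` differs from compound 1 in one place: piperidin-4-yl in place of phenyl on an aromatic carbon. Among the measured compounds shown here, two measured steps bear on this position. The step from compound 1 to compound 3 shows that the phenyl itself contributes little, so whatever replaces it starts from roughly the level of compound 3. The step from compound 1 to compound 2 shows that a changed group at this position can shift the number modestly. For the measured compounds named here, no measured step involves a piperidin-4-yl, so the expected step in this assay is a 1.5-fold lower number from compound 1 to compound 4 (0.19 log units; within the scatter), a small shift toward lower numbers at most. Compound 4 is therefore estimated at 300000 nM, within 60000 nM to 1000000 nM.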

Compound 4, half-maximal inhibitory concentration: 476000 nM
Beside the measured number, compound 4's estimate is 1.6-fold (0.20 log units) below it; low and high end bracket the measured number.
By their numbers in this assay, from the lowest: compound 2; then compounds 3, 1 and 4 (each within the scatter of the next).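

At this aromatic carbon of the five-membered ring, an aromatic ring of carbon only can give way to a non-aromatic ring carrying a nitrogen, with its hydrogen-bond donor and acceptor, without any change beyond the scatter in this assay (a 1.0-fold higher number from compound 1 to compound 4 (0.01 log units; within the scatter)), and the same holds when piperidin-4-yl is set against plain hydrogen (a 1.2-fold higher number from compound 3 to compound 4 (0.10 log units; within the scatter)). Hydrogen, phenyl and piperidin-4-yl therefore read alike here, and among the groups shown only the 4-fluorophenyl of compound 2 stands apart (an 8.0-fold higher number from compound 2 to compound 4 (0.90 log units; beyond the scatter)). Nothing measured here explains this pattern.

Still open, going by these compounds, is whether a chloro or a methoxy in place of the fluoro on that phenyl would give a step like that of compound 2. Also open, on these data alone, is whether an aminomethyl or a carboxylic acid on this carbon would read like hydrogen or like the 4-fluorophenyl.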